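Moving the Methoxy Group: From Compound 2 to Compound 3

This account rests on a few compounds, and the source may have more. Where it says the series, first, only, none or still open, it means among the compounds named here.

For the measured compounds named here, compound 2 `Clc1ccc(-c2cn3ccnc3c(-c3ccc4ncn(C5CCCCC5)c4c3)n2)cc1` gives 18.5% in a functional assay on SR cells (Homo sapiens) for inhibition, read by sulforhodamine B assay, with a stated time of 48 h, tested at 10 uM (a lower number here means less inhibition, a higher number more inhibition at the concentration tested (going by the name of the read-out)), the lowest of the two numbers measured so far. Going by the values given here, compound 1 `COc1ccc(-c2cn3ccnc3c(-c3ccc4ncn(C5CCCCC5)c4c3)n2)cc1` gives 91.7% in this assay, and the single measured step, a number 73.2 percentage points lower from compound 1 to compound 2 (beyond the scatter), shows how costly chloro in place of methoxy was. Compound 3 `COc1ccccc1-c1cn2ccnc2c(-c2ccc3ncn(C4CCCCC4)c3c2)n1` differs from compound 2 by 2-methoxyphenyl in place of 4-chlorophenyl on an aromatic carbon. This reverses the chloro-for-methoxy swap while relocating the methoxy group, so the earlier step bears on it only partly; a large rise in this assay is expected, with wide uncertainty. Compound 3 is estimated at 60%, within 20% to 95%. The expected step is a number 41.5 percentage points higher from compound 2 to compound 3 (beyond the scatter).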

Compound 3, a percentage reported as inhibition, at one concentration (the size of the read-out at that concentration, not a potency): 26.3%
Estimate against measurement, compound 3: 33.7 percentage points above; low and high end bracket the measured number.
By their numbers in this assay, from the lowest: compounds 2 and 3 (each within the scatter of the next); then compound 1.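

In this assay, relocating the methoxy group gives a number 65.4 percentage points lower from compound 1 to compound 3 (beyond the scatter) and so loses most of the inhibition, which shows that 4-methoxyphenyl and 2-methoxyphenyl are far from interchangeable at this position. The presence of a methoxy group is therefore not enough on its own. Replacing 4-chlorophenyl with 2-methoxyphenyl gives only a number 7.8 percentage points higher from compound 2 to compound 3 (within the scatter) and leaves the two compounds indistinguishable. Nothing available explains why the two methoxyphenyl groups differ so sharply.

On these data alone, whether 3-methoxyphenyl, 4-ethoxyphenyl or 4-aminophenyl would retain the inhibition remains open.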